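Replacing the urea nitrogen with a cyclopropyl carbonyl

The compounds below may be only part of what the source reports. "The series", "measured", "known", "first", "only" and "open" are said of these compounds alone.

The compounds measured in an assay on HEK293 cells for displacement of a labelled ligand from Type-2 angiotensin II receptor (Homo sapiens), read by scintillation counting, with a stated time of 240 min (a lower number here means a stronger inhibitor, a higher number a weaker inhibitor), are:
compound 1, `CCOC(=O)NS(=O)(=O)c1sc(CC(C)C)cc1-c1cccc(Cn2ccnc2)c1`, with 300 nM
compound 2, `CC(C)CCOC(=O)NS(=O)(=O)c1sc(CC(C)C)cc1-c1cccc(Cn2ccnc2)c1`, with 230 nM
compound 3, `CCN(CC)C(=O)NS(=O)(=O)c1sc(CC(C)C)cc1-c1cccc(Cn2ccnc2)c1`, with 2300 nM

Compound 3 stands at the highest number of the three. The two carbamates lie close to each other, the step of a 1.3-fold lower number from compound 1 to compound 2 (0.12 log units; within the scatter) staying inside the scatter, while the urea sits well apart: a 7.7-fold higher number from compound 1 to compound 3 (0.88 log units; beyond the scatter) and a 10-fold higher number from compound 2 to compound 3 (1.00 log units; beyond the scatter) both go beyond it.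

Compound 4, `CC(C)Cc1cc(-c2cccc(Cn3ccnc3)c2)c(S(=O)(=O)NC(=O)C2CC2)s1`, carries cyclopropyl in place of diethylamino on a carbonyl carbon. Among the measured compounds shown here, no measured step exchanges the diethylamino for a carbon substituent, so the comparison is indirect: the only change that has touched this carbonyl carbon, from ethoxy or isopentyloxy to diethylamino, raised the number by a modest amount, and the reverse direction away from diethylamino is the one compound 4 takes. A step back toward the carbamate range is therefore expected, though its size is uncertain; the expected step is a 4.6-fold lower number from compound 3 to compound 4 (0.66 log units; beyond the scatter). Compound 4 is estimated at 500 nM, with a range from 150 nM to 2000 nM.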

Compound 4, inhibition constant: 340 nM
Compound 4: middle estimate off by 1.5-fold (0.17 log units), on the high side; the measured number falls inside the stated range.
By their numbers in this assay, from the lowest: compounds 2, 1 and 4 (each within the scatter of the next); then compound 3.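

In this assay, among the compounds shown here, the exchange at this carbonyl carbon gives a 6.8-fold lower number from compound 3 to compound 4 (0.83 log units; beyond the scatter), the first direct measurement of a step away from diethylamino. The carbonyl carbon also proves able to carry a cyclopropyl group with no oxygen attached in place of the alkoxy groups: a 1.1-fold higher number from compound 1 to compound 4 (0.05 log units; within the scatter) and a 1.5-fold higher number from compound 2 to compound 4 (0.17 log units; within the scatter) both stay within the scatter, which leaves compound 3 alone apart from the other three. No evidence here bears on what lies behind these steps.

The compounds shown leave open whether the higher number of compound 3 goes with the nitrogen on the carbonyl carbon or with its ethyl groups, a question that a methylamino or a pyrrolidinyl group there would address. They also leave open how a cyclobutyl, a cyclohexyl or a phenyl group on this carbonyl carbon would compare with cyclopropyl.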